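Moving the ring nitrogen in a diaryl urea

This account rests on a few compounds, and the source may have more. Where it says the series, first, only, none or still open, it means among the compounds named here.

The measured compounds in a physicochemical assay for lipophilicity, read by HPLC, measured as octanol-water partition, at pH 7.2; a higher number here means a more lipophilic compound, a lower number a more polar compound:
compound 1, `O=C(Nc1ccc(F)c(C(F)(F)F)c1)Nc1ccccn1`, gives 3.7
compound 2, `NC(=O)c1ccccc1NC(=O)Nc1ccc(F)c(C(F)(F)F)c1`, gives 3.3
compound 3, `CC(=O)c1ccc(NC(=O)Nc2ccc(F)c(C(F)(F)F)c2)cc1`, gives 3.6

Compound 1 has the highest of the three numbers. Its nearest neighbour is compound 3, whose value lies lower by an amount within the scatter, so the two cannot be told apart; compound 2 lies furthest away, lower by an amount beyond the scatter. The three share the same fluoro- and trifluoromethyl-bearing aryl urea portion and differ only in the second aryl group, so the spread seen here comes from that side alone.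

Compound 4, `O=C(Nc1cccnc1)Nc1ccc(F)c(C(F)(F)F)c1`, has not yet been measured. It has the same atoms as compound 1, joined differently: pyridin-3-yl in place of pyridin-2-yl on an amide-type nitrogen. Cut one bond further out, the change reads (pyridin-2-yl)amino to (pyridin-3-yl)amino.

Among the measured compounds shown here, no measured pair shows this exact change. Compound 4 is expected to give a somewhat lower number in this assay than compound 1, with a step of a number 0.40 log units lower from compound 1 to compound 4 (beyond the scatter) that may not clearly exceed the scatter. Compound 4 is estimated at 3.3, between 2.9 and 3.7.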

Compound 4, distribution coefficient: 3
Compound 4: middle estimate off by 0.30 log units, on the high side; low and high end bracket the measured number.
By their numbers in this assay, from the lowest: compounds 4, 2, 3 and 1 (each within the scatter of the next, the first and the last beyond it).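

In this assay, among the compounds shown here, moving the ring nitrogen alone gives a number 0.70 log units lower from compound 1 to compound 4 (beyond the scatter) and this is the first step that can be read between two compounds differing in one place. The earlier compounds shown here differ in the whole second aryl group, whereas here the atoms stay the same and only their joining changes, from pyridin-2-yl to pyridin-3-yl on an amide-type nitrogen, with the counts of hydrogen-bond donors and acceptors in the group unchanged. Nothing shown here accounts for the size of this step.

The compounds shown leave open where pyridin-4-yl would fall on this scale, and whether a methyl group or an amine on the pyridine ring would alter the step. They also leave open whether the same change gives a similar step on a urea with a different aryl partner.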